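A few compounds are considered here, and "the series" means these few. Any claim that something is new, unique, unknown or untested is made for them only; others in the source may bear on it.

Compound 2 `COC(=O)/C=C/c1cccc(N(Cc2ccc(-c3ccc(F)c(Cl)c3)cc2)C(=O)C2CCCCC2)c1` is one of two measured compounds, and its number lies within the scatter of the other: in an assay on isolated protein with Bile acid receptor (Homo sapiens) as the target (a higher number here means that more compound is needed for the effect, a lower number that less compound is needed), compound 2 gives 66 nM, while compound 1 `COC(=O)/C=C/c1cccc(N(Cc2ccc(-c3ccc(OC)cc3)cc2)C(=O)C2CCCCC2)c1` gives 89 nM, a change of a 1.3-fold lower number from compound 1 to compound 2 (0.13 log units; within the scatter). Compound 3 `COC(=O)/C=C/c1cccc(N(Cc2ccc(-c3ccc(C(C)(C)C)cc3)cc2)C(=O)C2CCCCC2)c1` differs from compound 2 by 4-(tert-butyl)phenyl in place of 3-chloro-4-fluorophenyl on an aromatic carbon. For the measured compounds named here, only the step from compound 1 to compound 2 bears on this, since it also swapped the group on that aromatic carbon, and it stayed within the scatter. So no change beyond the scatter is expected, an estimated step of a 1.1-fold higher number from compound 2 to compound 3 (0.03 log units; within the scatter). Compound 3 is estimated at 70 nM, within a range from 35 nM to 140 nM.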

Compound 3, half-maximal effective concentration: 132 nM
The estimate for compound 3 lay 1.9-fold (0.28 log units) below the measured number; the measured number falls inside the stated range.
By their numbers in this assay, from the lowest: compounds 2, 1 and 3 (each within the scatter of the next).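

The all-carbon 4-(tert-butyl)phenyl group also fits at this position: its replacement of 3-chloro-4-fluorophenyl gives a 2.0-fold higher number from compound 2 to compound 3 (0.30 log units; within the scatter), and tert-butyl in place of methoxy gives a 1.5-fold higher number from compound 1 to compound 3 (0.17 log units; within the scatter). With a third, different group, every step at this position still lies within the scatter, so the swaps shown here do not separate these compounds. No outside measurement offers an explanation for these numbers. On these data alone, whether an amine or a carboxylic acid at this position would give a step beyond the scatter remains open.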